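The source may hold more compounds than are shown below. What is called first, only, known or untested is meant among the compounds shown, and "the series" means these compounds.

Compound 1 `Nc1ncnc2c1ncn2CC(O)C(=O)OC1CCCCC1` carries a cyclohexyl on an oxygen next to a carbonyl group, attached through a short linker to the shared core. Among the measured compounds shown here, in a functional assay on PRK cells (Oryctolagus cuniculus) for cytotoxicity (on this read-out lower numbers stand for higher toxicity in this test and higher numbers for lower toxicity in this test), compound 1 gives 100 ug/mL, which is the higher, less toxic of the two numbers measured so far. Compound 2 `Nc1ncnc2c1ncn2CC(O)C(=O)OCc1ccco1` replaces that cyclohexyl with a (furan-2-yl)methyl, and in this assay compound 2 gives 40 ug/mL. For the measured compounds named here, the single measured step, a 2.5-fold lower number from compound 1 to compound 2 (0.40 log units; beyond the scatter), is modest but beyond the scatter and goes toward higher toxicity.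

Compound 3 `CC(C)(C)OC(=O)C(O)Cn1cnc2c(N)ncnc21` has not yet been tested. Its difference from compound 1 is tert-butyl in place of cyclohexyl on an oxygen next to a carbonyl group. Going by the values given here, the only measured step exchanged the cyclohexyl for a ring-bearing group, whereas here the ring disappears and a small branched alkyl takes its place, so that step offers no direct guide to direction. With no comparable change measured, the step from compound 1 to compound 3 is expected to stay within the scatter, that is no change at the digits printed from compound 1 to compound 3 (within the scatter). For compound 3 the estimated value in this assay is 100 ug/mL, expected to fall between 40 ug/mL and 250 ug/mL.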

Compound 3, minimum cytotoxic concentration: > 400 ug/mL
Compound 3 was reported as a limit; the forecaster's own chance of this, stated with the estimate: 15%; middle value at least 4.0-fold (0.60 log units) away from the limit.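

The reading for compound 3 in this assay is a limit and not an exact number: the limit of > 400 ug/mL in this assay, at which 1 of the 3 values shown sits.

Tert-butyl in place of cyclohexyl on an oxygen next to a carbonyl group gives an at least 4.0-fold higher number from compound 1 to compound 3 (0.60 log units; beyond the scatter), and tert-butyl in place of (furan-2-yl)methyl gives an at least 10-fold higher number from compound 2 to compound 3 (1.00 log units; beyond the scatter). The earlier pair showed only a move toward higher toxicity in this test, whereas these steps show that a change at this position can also move the number clearly the other way, with tert-butyl, the one group shown without a ring, on the less toxic side of both ring-bearing groups.

The compounds shown cannot separate the loss of the ring from the branching of tert-butyl, since these two features change together in the same step. On these data alone, how an unbranched butyl chain, a phenyl ring or a longer alkyl chain on this oxygen would compare remains open, as does the effect of a carboxylic acid or an amide in place of this ester.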